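Fluoro for methoxy: from compound 3 to compound 4

The compounds below may be only part of what the source reports. "The series", "measured", "known", "first", "only" and "open" are said of these compounds alone.

In a functional assay on SW-620 cells (Homo sapiens) for cytotoxicity (on this read-out higher numbers stand for weaker inhibition of growth and lower numbers for stronger inhibition of growth), compound 3 `COc1ccc(C2=C(c3ccc(SC)cc3)CC3CCCN3C2=O)cc1` gives 3000 nM, within the scatter of compound 1 `COc1ccc(C2=C(c3ccc(SC)cc3)CC3CCCN3C2=O)cc1Br` at 5000 nM and well above compound 2 `CSc1ccc(C2=C(c3ccc(F)c(F)c3)C(=O)N3CCCC3C2)cc1` at 200 nM. Compound 4 `CSc1ccc(C2=C(c3ccc(F)cc3)C(=O)N3CCCC3C2)cc1` keeps the shared core and differs from compound 3 by one change: fluoro in place of methoxy on an aromatic carbon. This places fluoro in place of methoxy on an aromatic carbon, para to a large group.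

The closest measured step is a 15-fold higher number from compound 2 to compound 3 (1.18 log units; beyond the scatter), a large one that brings in 4-methoxyphenyl in place of 3,4-difluorophenyl. The step of a 25-fold lower number from compound 1 to compound 2 (1.40 log units; beyond the scatter) is also large, whereas a 1.7-fold lower number from compound 1 to compound 3 (0.22 log units; within the scatter), hydrogen in place of bromo, stays within the scatter. Fluorinated phenyl has so far been measured only in compound 2, so a single fluoro remains untested. A sizeable move to a lower number in this assay is nevertheless expected, and the estimated step is a 7.5-fold lower number from compound 3 to compound 4 (0.88 log units; beyond the scatter). For compound 4 the estimated value is 400 nM, with an expected range of 130 nM to 1200 nM.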

Compound 4, concentration for 50% growth inhibition: 500 nM
Compound 4: the middle estimate sits 1.3-fold (0.10 log units) below what was measured; low and high end bracket the measured number.
By their numbers in this assay, from the lowest: compound 2; then compound 4; then compounds 3 and 1 (each within the scatter of the next).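

In this assay a single fluoro in this place already accounts for most of the distance between compound 3 and compound 2, so the change from 4-methoxyphenyl to 4-fluorophenyl no longer has to be read together with a second fluoro (a 6.0-fold lower number from compound 3 to compound 4 (0.78 log units; beyond the scatter)). The second fluoro still counts, since hydrogen in its place leaves a step beyond the scatter (a 2.5-fold higher number from compound 2 to compound 4 (0.40 log units; beyond the scatter)), and the same 4-fluorophenyl ring also separates the bromo compound from the fluoro series (a 10-fold lower number from compound 1 to compound 4 (1.00 log units; beyond the scatter)). Nothing among the available data explains these differences.

The compounds shown leave open whether fluoro itself matters here or whether the loss of methoxy is enough, which plain hydrogen, chloro or a nitrile in this place would settle. From the compounds shown here alone, it also remains open how a hydroxyl, an amine or a carboxylic acid would read there.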